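From chloro to methoxy on the shared core

This account rests on a few compounds, and the source may have more. Where it says the series, first, only, none or still open, it means among the compounds named here.

Compound 1 (`Oc1cccc(-c2nc3cc(F)ccc3s2)c1`) gives (570 nM)
Compound 2 (`Oc1ccc(-c2nc3cc(C(F)(F)F)ccc3s2)cc1`) gives (13800 nM)
Compound 3 (`Oc1ccc(-c2nc3ccc(Cl)cc3s2)cc1`) gives (26500 nM)

All three compounds were tested in a functional assay on MCF7 cells (Homo sapiens) for inhibition (a higher number here means a weaker inhibitor, a lower number a stronger inhibitor), and can be compared directly. Compound 3 (26500 nM) and compound 2 (13800 nM) lie within the usual scatter of each other, so neither can be ranked above the other. Compound 1 (570 nM) has a much lower number than compound 3, a gap well beyond the scatter, which makes it the stronger inhibitor of that pair.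

Compound 4 (`COc1ccc2nc(-c3ccc(O)cc3)sc2c1`) has methoxy in place of chloro on an aromatic carbon. For the measured compounds named here, no two measured compounds differ in just one place, so no direct precedent exists for this swap. The closest guide is a comparison of two compounds with different groups on the shared core: compound 2 with trifluoromethyl (13800 nM) and compound 3 with chloro (26500 nM) remain within the scatter of each other. Compound 1 differs from compound 3 in more than one place, so it offers little guidance here. The expected 1.5-fold lower number from compound 3 to compound 4 (0.17 log units; within the scatter) is small and stays within the scatter, with no clear direction. The estimate for compound 4 is 18000 nM with an expected range from 5000 nM to 60000 nM (an estimate, not a measurement).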

Compound 4, half-maximal inhibitory concentration: 45800 nM
Beside the measured number, compound 4's estimate is 2.5-fold (0.41 log units) below it, and the stated range covers the measured number.
By their numbers in this assay, from the lowest: compound 1; then compounds 2, 3 and 4 (each within the scatter of the next, the first and the last beyond it).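

In this assay, for the compounds shown here, methoxy in place of chloro on an aromatic carbon gives a 1.7-fold higher number from compound 3 to compound 4 (0.24 log units; within the scatter) and so forms the first pair in this set that differs in one place only. At this position, the two groups cannot be told apart in this assay, even though methoxy brings more heavy atoms and a hydrogen-bond acceptor, which chloro does not have. No supporting measurement is available to explain this result.

Going by these compounds alone, this single pair covers only two groups at one position, so it cannot show how sensitive that position is in general. On these data alone, whether an amine or a carboxylic acid on the same aromatic carbon would give a number beyond the scatter from compound 3 remains open, as does whether methoxy in place of chloro would give a similar result on a core with its hydroxy group placed as in compound 1.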